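The compounds below may be only part of what the source reports. "The series", "measured", "known", "first", "only" and "open" are said of these compounds alone.

Compound 1, `O=C(Nc1ccc(Oc2ccnc3[nH]ccc23)cc1)c1cc2cccnc2n(-c2ccc(F)cc2)c1=O`, gives 190 nM.
Compound 2, `COc1ccc(-n2c(=O)c(C(=O)Nc3ccc(Oc4ccnc5[nH]ccc45)cc3)cc3cccnc32)cc1`, gives 960 nM.
Compound 3, `Cn1ccc2c(Oc3ccc(NC(=O)c4cc5cccnc5n(-c5ccc(F)cc5)c4=O)cc3)ccnc21`, gives 260 nM.

All three were tested in a functional assay on NCI-H460 cells (Homo sapiens) for antiproliferative activity, read by MTT assay, with a stated time of 72 h; a lower number here means a stronger inhibitor, a higher number a weaker inhibitor. Among them compound 3 stands second highest; its nearest neighbour is compound 1, with a gap that lies within the scatter, while compound 2 lies furthest from it, beyond the scatter. Compound 4, `COc1ccc(-n2c(=O)c(C(=O)Nc3ccc(Oc4ccnc5c4ccn5C)cc3)cc3cccnc32)cc1`, has not yet been measured. It differs from compound 3 in one place: methoxy in place of fluoro on an aromatic carbon. For the measured compounds named here, one measured step bears directly on this change, since the same swap of fluoro for methoxy on the shared core gave a 5.1-fold higher number from compound 1 to compound 2 (0.70 log units; beyond the scatter). The other step, a 1.4-fold higher number from compound 1 to compound 3 (0.14 log units; within the scatter), is within the scatter, so the methyl on the aromatic nitrogen that compound 3 and compound 4 share is not expected to alter the picture. A weakening of similar size is therefore expected, and compound 4 is estimated at 1300 nM, in the range 500 nM to 3500 nM, corresponding to an expected step of a 5.0-fold higher number from compound 3 to compound 4 (0.70 log units; beyond the scatter).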

Compound 4, half-maximal inhibitory concentration: 1920 nM
For compound 4 the middle estimate is 1.5-fold (0.17 log units) below the measured one; low and high end bracket the measured number.
By their numbers in this assay, from the lowest: compounds 1 and 3 (each within the scatter of the next); then compounds 2 and 4 (each within the scatter of the next).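

In this assay the change from 4-fluorophenyl to 4-methoxyphenyl also weakens a second core, giving a 7.4-fold higher number from compound 3 to compound 4 (0.87 log units; beyond the scatter) on that core, so the loss is not confined to the core of compound 1. The two losses agree in size: the same change on two cores in this assay, a 5.1-fold higher number (0.70 log units; beyond the scatter) from compound 1 to compound 2 and a 7.4-fold higher number (0.87 log units; beyond the scatter) from compound 3 to compound 4, 1.5-fold (0.16 log units) apart, within the scatter of two such steps. The methyl on the aromatic nitrogen still makes no clear difference with methoxy in place, giving a 2.0-fold higher number from compound 2 to compound 4 (0.30 log units; within the scatter) and matching its step in the fluoro pair: the same change on two cores in this assay, a 1.4-fold higher number (0.14 log units; within the scatter) from compound 1 to compound 3 and a 2.0-fold higher number (0.30 log units; within the scatter) from compound 2 to compound 4, 1.5-fold (0.16 log units) apart, within the scatter of two such steps.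

On these data alone, only fluoro and methoxy appear at this position, so it remains open how a plain hydrogen, a chloro, a hydroxyl or an amine would fare there. What lies behind the loss with methoxy cannot be told from these two groups alone.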